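Methoxy for Methylamino on a Carbonyl Carbon

This account rests on a few compounds, and the source may have more. Where it says the series, first, only, none or still open, it means among the compounds named here.

For the measured compounds named here, in a functional assay on WM 266-4 cells (Homo sapiens) for inhibition, with a stated time of 72 h (a higher number here means a weaker inhibitor, a lower number a stronger inhibitor), compound 1 `CNC(=O)C1=C[C@@H]2[C@@H](C(C)C)CC[C@@]3(CO3)[C@H]2C(=O)OC1` gives 5900 nM, the only exact number so far. Compound 2 `CNC(=O)C1=C[C@@H]2[C@@H](C(C)C)CC[C@@](O)(CO)[C@H]2C(=O)OC1` reads > 32000 nM in this assay, and this is a limit of the assay rather than a number. Compound 3 `COC(=O)C1=C[C@@H]2[C@@H](C(C)C)CC[C@@]3(CO3)[C@H]2C(=O)OC1` keeps the core of compound 1 but carries methoxy in place of methylamino on a carbonyl carbon. Going by the values given here, no pair of measured compounds shows this change, so its size cannot be read from the data. Starting from compound 1 at 5900 nM, a modest move towards stronger inhibition in this assay is expected, close to the usual scatter. The expected step is a 2.0-fold lower number from compound 1 to compound 3 (0.29 log units; within the scatter). For compound 3, the estimated value is 3000 nM, with an expected range of 700 nM to 13000 nM.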

Compound 3, half-maximal inhibitory concentration: 4100 nM
For compound 3 the middle estimate is 1.4-fold (0.14 log units) below the measured one; the range from low to high includes it.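

In this assay, for the compounds shown here, replacing methylamino by methoxy on this carbonyl carbon gives a 1.4-fold lower number from compound 1 to compound 3 (0.16 log units; within the scatter) and this is the first direct reading of the position. The amide hydrogen of compound 1 is absent from compound 3, so a hydrogen-bond donor at this place is not needed for the inhibition seen, at least on this core. Nothing in the data explains why the two groups read alike.

On these data alone, whether this position accepts larger or quite different changes remains open: a carboxylic acid, a primary amide or a longer chain such as ethoxy would each test that. Also open, as far as these compounds go, is whether the same swap would read alike on compound 2, whose result is only a limit of the assay.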